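Moving the Fluorines on the Benzyl Group of Compound 2

The source may report more compounds than this note shows. Statements on the series, on what has been measured and on what is new or still open speak of the compounds shown alone.

Compound 1 `CC(C)(C)c1cc(/C=C/C(=O)NCCC2CCN(Cc3ccccc3F)CC2)cc(C(C)(C)C)c1O`: 7400 nM
Compound 2 `CC(C)(C)c1cc(/C=C/C(=O)NCCC2CCN(Cc3ccc(F)cc3F)CC2)cc(C(C)(C)C)c1O`: 12500 nM

Both compounds were tested in an assay on isolated protein for inhibition of Amine oxidase [flavin-containing] B (Homo sapiens), read by fluorescence, with stated times of 15 min and 20 min; a lower number here means a stronger inhibitor, a higher number a weaker inhibitor. Compound 2 gives the highest of the two numbers; its nearest neighbour is compound 1, and the step of a 1.7-fold higher number from compound 1 to compound 2 (0.23 log units; within the scatter) lies within the scatter, so the two values are not distinguishable.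

Compound 3 `CC(C)(C)c1cc(/C=C/C(=O)NCCC2CCN(Cc3ccc(F)c(F)c3)CC2)cc(C(C)(C)C)c1O` differs from compound 2 by 3,4-difluorophenyl in place of 2,4-difluorophenyl on a saturated chain carbon bound to an amine nitrogen in a ring. Among the measured compounds shown here, only one measured step has any bearing on this change, a 1.7-fold higher number from compound 1 to compound 2 (0.23 log units; within the scatter), and it stayed within the scatter. For the measured compounds named here, no measured step rearranges the two fluorines on the ring, so nothing in the data points to a direction. Compound 3 is therefore expected to sit within the scatter of compound 2, with the step of a 1.3-fold lower number from compound 2 to compound 3 (0.10 log units; within the scatter) being small. Compound 3 is estimated at 10000 nM, with a range from 4000 nM to 25000 nM.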

Compound 3, half-maximal inhibitory concentration: 9300 nM
For compound 3 the middle estimate is 1.1-fold (0.03 log units) above the measured one, and the stated range covers the measured number.
By their numbers in this assay, from the lowest: compounds 1, 3 and 2 (each within the scatter of the next).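

Among the compounds shown here, this is the first measured step that rearranges the two fluorines on the ring instead of adding one: in this assay, 3,4-difluorophenyl in place of 2,4-difluorophenyl gives a 1.3-fold lower number from compound 2 to compound 3 (0.13 log units; within the scatter) and so leaves the two arrangements indistinguishable. The 3,4-difluorobenzyl group also cannot be told apart from the single-fluorine benzyl group of compound 1, with a 1.3-fold higher number from compound 1 to compound 3 (0.10 log units; within the scatter) between them, so the three fluorinated benzyl groups shown all read alike. No measurement at hand offers an explanation for this result.

The compounds shown leave open whether a plain benzyl group without fluorine, or a benzyl group carrying chlorine or methoxy, would read any differently from these three. Also open, going by these compounds, is whether a longer chain in the linker of the shared core would shift these numbers.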